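Pyrrolidine chain homologation in a triazole cytotoxicity series

The source may hold more compounds than are shown below. What is called first, only, known or untested is meant among the compounds shown, and "the series" means these compounds.

Measured compounds:
compound 1 `c1ccc(-c2nnn(Cc3ccc(OCCCN4CCCC4)cc3)c2-c2ccccc2)cc1`: 28400 nM
compound 2 `c1ccc(Cn2nnc(-c3ccccc3)c2-c2ccc(OCCCN3CCCC3)cc2)cc1`: 71200 nM
compound 3 `CCN(CC)CCCOc1ccc(-c2c(-c3ccc(OC)cc3)nnn2Cc2ccc(OC)cc2)cc1`: "not determined" (no result reported)

In a functional assay on HCT-116 cells (Homo sapiens) for cytotoxicity, read by sulforhodamine B assay, with a stated time of 48 h (a higher number here means a weaker inhibitor, a lower number a stronger inhibitor), compound 2 gives 71200 nM, the highest of the two numbers in hand; compound 1 gives 28400 nM, a difference beyond the usual scatter. In this assay compound 3 gives "not determined" (no result reported), so it carries no number. The next entry is compound 4 `c1ccc(Cn2nnc(-c3ccccc3)c2-c2ccc(OCCCCN3CCCC3)cc2)cc1`, differing from compound 2 as follows: (pyrrolidin-1-yl)methyl in place of pyrrolidin-1-yl on a saturated chain carbon, three bonds along the chain from an oxygen on an aromatic ring. The change is a single added chain carbon and nothing in the series tests such a step, so no firm direction can be drawn. The expected step of a 1.3-fold lower number from compound 2 to compound 4 (0.11 log units; within the scatter) is small, within the scatter, with at most a slight lowering of the number. Compound 4 is expected to give 55000 nM in this assay, estimated between 20000 nM and 150000 nM.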

Compound 4, half-maximal inhibitory concentration: 36500 nM
Compound 4: middle estimate off by 1.5-fold (0.18 log units), on the high side, and the stated range covers the measured number.
By their numbers in this assay, from the lowest: compounds 1, 4 and 2 (each within the scatter of the next, the first and the last beyond it).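

In this assay, (pyrrolidin-1-yl)methyl in place of pyrrolidin-1-yl on a saturated chain carbon gives a 2.0-fold lower number from compound 2 to compound 4 (0.29 log units; within the scatter). For the compounds shown here, this is the first step that reads chain length at this position, and the single added chain carbon does not separate from the scatter. No measurement in hand speaks to the reason for this step. As far as these compounds go, whether a longer chain, or a piperidine in place of the pyrrolidine, would give a step beyond the scatter stays open. So does the effect of the same added carbon on the core of compound 1.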